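The source may report more compounds than this note shows. Statements on the series, on what has been measured and on what is new or still open speak of the compounds shown alone.

Measured compounds in a physicochemical assay for solubility, measured as kinetic solubility, with a stated time of 15 h, at pH 7.4; a lower number here means a less soluble compound, a higher number a more soluble compound:
compound 1 `OC[C@H]1O[C@H](Oc2ccc(-c3ccc(Cl)cc3Cl)cc2Cl)[C@@H](O)[C@@H](O)[C@@H]1O`: 8 ug/mL
compound 2 `OC[C@H]1O[C@H](Oc2ccc(-c3ccc(Cl)c(C(F)(F)F)c3)cc2Cl)[C@@H](O)[C@@H](O)[C@@H]1O`: 1 ug/mL
compound 3 `O=[N+]([O-])c1cccc(-c2ccc(O[C@H]3O[C@H](CO)[C@@H](O)[C@H](O)[C@@H]3O)c(Cl)c2)c1`: 23 ug/mL

Compound 3 stands highest of the three numbers; compound 1 is nearest and compound 2 furthest, both lower and both beyond the scatter. Compound 4 `OC[C@H]1O[C@H](Oc2ccc(-c3ccc(Cl)cc3)cc2Cl)[C@@H](O)[C@@H](O)[C@@H]1O` is not yet measured in this assay. Its difference from compound 3: 4-chlorophenyl in place of 3-nitrophenyl on an aromatic carbon. Among the measured compounds shown here, the one measured step at this position is a 2.9-fold higher number from compound 1 to compound 3 (0.46 log units; beyond the scatter), a modest rise on the same ring. Compound 4 carries neither the 3-nitrophenyl of compound 3 nor the 2,4-dichlorophenyl of compound 1, so a modest fall from compound 3 that stops short of the number of compound 1 is expected. Compound 4 is expected to give 12 ug/mL in this assay, within 4 ug/mL to 30 ug/mL. The expected step is a 1.9-fold lower number from compound 3 to compound 4 (0.28 log units; within the scatter).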

Compound 4, solubility: 3.5 ug/mL
The estimate for compound 4 lay 3.4-fold (0.54 log units) above the measured number, outside the stated range (below it).
By their numbers in this assay, from the lowest: compound 2; then compound 4; then compound 1; then compound 3.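

In this assay, among the compounds shown here, hydrogen in place of chloro gives a 2.3-fold lower number from compound 1 to compound 4 (0.36 log units; beyond the scatter) and hydrogen in place of trifluoromethyl gives a 3.5-fold higher number from compound 2 to compound 4 (0.54 log units; beyond the scatter) on the same outer ring, so losing a substituent there does not move the number in one direction. 4-Chlorophenyl in place of 3-nitrophenyl gives a 6.6-fold lower number from compound 3 to compound 4 (0.82 log units; beyond the scatter) and leaves 3-nitrophenyl as the only group here above compound 1. Nothing available explains these steps.

Open, on these data alone, is how an amine or a carboxylic acid on this ring would compare with 3-nitrophenyl. Also open, as far as these compounds go, is whether a nitro group elsewhere on the ring would match it.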